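The source may hold more compounds than are shown below. What is called first, only, known or untested is meant among the compounds shown, and "the series" means these compounds.

Working notes on the series. Compound 1 `Cc1cc(Oc2ccccc2)c(S(C)(=O)=O)cc1C(=O)N=C(N)N` is the parent; in a functional assay for inhibition of sodium/hydrogen exchanger (Oryctolagus cuniculus) (a lower number here means a stronger inhibitor, a higher number a weaker inhibitor), compound 1 gives 10 nM. Compound 2 `Cc1cc(Oc2ccccc2Cl)c(S(C)(=O)=O)cc1C(=O)N=C(N)N` carries chloro in place of hydrogen on an aromatic carbon and in this assay compound 2 gives 14 nM, a step of a 1.4-fold higher number from compound 1 to compound 2 (0.15 log units; within the scatter). Compound 3 `Cc1cc(Oc2cccnc2)c(S(C)(=O)=O)cc1C(=O)N=C(N)N` in this assay gives 8.8 nM. All three values lie within the scatter of one another, so no order among compounds 1, 2 and 3 can be read from them.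

Compound 4 `Cc1cc(Oc2cncc(Cl)c2)c(S(C)(=O)=O)cc1C(=O)N=C(N)N` is not yet measured. It differs from compound 3 by chloro in place of hydrogen on an aromatic carbon. This is the same kind of change as that from compound 1 to compound 2, not the same change: in the earlier pair the chloro entered on a six-membered aromatic ring of carbon only, ortho to a large group, whereas here it enters on a six-membered aromatic ring with 1 nitrogen, two atoms from the ring nitrogen, meta to a large group. The cores differ by pyridin-3-yl in place of phenyl on an oxygen on an aromatic ring.

Among the compounds with values here, the single measured precedent is the step of a 1.4-fold higher number from compound 1 to compound 2 (0.15 log units; within the scatter), which stayed within the scatter. A step of similar size is therefore expected, a 1.4-fold higher number from compound 3 to compound 4 (0.13 log units; within the scatter). Compound 4 is estimated at 12 nM, with a range from 6 nM to 25 nM. This estimate rests on that precedent and on compound 3 at 8.8 nM.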

Compound 4, half-maximal inhibitory concentration: 14 nM
The estimate for compound 4 lay 1.2-fold (0.07 log units) below the measured number; measured number inside the range.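

In this assay the chloro group carries from the core of compound 1 to the core of compound 3 with steps that do not differ: the same change on two cores in this assay, a 1.4-fold higher number (0.15 log units; within the scatter) from compound 1 to compound 2 and a 1.6-fold higher number (0.20 log units; within the scatter) from compound 3 to compound 4, 1.1-fold (0.06 log units) apart, within the scatter of two such steps. The step of a 1.6-fold higher number from compound 3 to compound 4 (0.20 log units; within the scatter) stands with no change at the digits printed from compound 2 to compound 4 (within the scatter) and with a 1.4-fold higher number from compound 1 to compound 4 (0.15 log units; within the scatter) as steps that all lie within the scatter, so compound 4 cannot be ordered against compound 1, compound 2 or compound 3. This shows that chloro in place of hydrogen stayed within the scatter on both cores, but it does not show that chloro has any effect of its own, nor does it separate core from place, since the chloro sits differently in the two pairs and two pairs set no rule for the series.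

The compounds shown carry only hydrogen or chloro on the ring held through the oxygen. Going by these compounds, how an amine, a carboxylic acid or a longer chain at that place would read in this assay stays open.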